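The compounds below may be only part of what the source reports. "The series", "measured", "known", "first", "only" and "open" are said of these compounds alone.

Within the data shown here, in a functional assay on MCF7 cells (Homo sapiens) for inhibition, with a stated time of 48 h, tested at 50 uM (on this read-out lower numbers stand for less inhibition of growth and higher numbers for more inhibition of growth at the one concentration tested), compound 1 `COc1ccccc1/C=C/[C@@](C)(/C=C/c1ccc(O)cc1)CCC=C(C)C` gives 42%, while compound 2 `COc1ccc(/C=C/[C@@](C)(/C=C/c2ccc(O)cc2)CCC=C(C)C)cc1` gives 55%, the highest of the two numbers so far. Compound 3 `COc1ccc(/C=C/[C@@](C)(/C=C/c2ccc(O)cc2)CCC=C(C)C)cc1C=O` has not yet been measured. It differs from compound 2 by formyl in place of hydrogen on an aromatic carbon, ortho to a methoxy group and meta to a large group. Among the measured compounds shown here, only one measured step bears on this change, and only loosely: a number 13 percentage points higher from compound 1 to compound 2 (beyond the scatter), which exchanges 2-methoxyphenyl for 4-methoxyphenyl. For the measured compounds named here, no measured compound carries a formyl group, so that modest step suggests only a rough size, and the data give no firm direction. The expected result is a number 5 percentage points lower from compound 2 to compound 3 (within the scatter), a small estimated change with a slight downward lean. For compound 3, the estimated value in this assay is 50%, with an expected range from 33% to 68%.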

Compound 3, percent growth inhibition at one concentration: 36%
The estimate for compound 3 lay 14 percentage points above the measured number; measured number inside the range.
By their numbers in this assay, from the lowest: compounds 3 and 1 (each within the scatter of the next); then compound 2.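

In this assay formyl in place of hydrogen on an aromatic carbon, ortho to a methoxy group and meta to a large group, gives a number 19 percentage points lower from compound 2 to compound 3 (beyond the scatter) and shows that this place on the ring of compound 2 does not tolerate the change without loss. The earlier step, a number 13 percentage points higher from compound 1 to compound 2 (beyond the scatter) with 2-methoxyphenyl exchanged for 4-methoxyphenyl, only moved the methoxy group, whereas this one adds a new group to the ring and points downward. No measurement at hand speaks to the reason for this drop.

The compounds shown leave open whether the loss belongs to formyl itself or to any group at this place, which a methyl, a hydroxymethyl or a carboxylic acid there would help to settle. They also leave open whether formyl would lower the number in the same way on the 2-methoxyphenyl ring of compound 1.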